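A few compounds are considered here, and "the series" means these few. Any claim that something is new, unique, unknown or untested is made for them only; others in the source may bear on it.

Compounds measured in an assay for inhibition of zeta-carotene desaturase, chloroplastic/chromoplastic (Capsicum annuum), using a Dixon plot, with a stated time of 8 h; on this read-out lower numbers stand for stronger inhibition and higher numbers for weaker inhibition:
compound 1 `CCC(COc1ccccc1Cl)OC(=O)NCc1ccccc1`: > 100000 nM, a limit of the assay rather than a number
compound 2 `CCC(COc1cccc(Cl)c1)OC(=O)NCc1ccccc1`: > 100000 nM, likewise a limit
compound 3 `CCC(COc1cccc(Cl)c1Cl)OC(=O)NCc1ccccc1`: > 100000 nM, likewise a limit

Compound 2 therefore stands at the limit of this assay, with no number of its own. The whole set sits there, as the limit of > 100000 nM in this assay, at which 3 of the 3 values shown sit, records. The three steps among the measured compounds, a step that the two limits leave unreadable from compound 1 to compound 2, a step that the two limits leave unreadable from compound 1 to compound 3 and a step that the two limits leave unreadable from compound 2 to compound 3, cannot be sized from two limits, so they give no reading of direction or magnitude.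

Compound 4 `CCC(COc1cccc(Cl)c1)OC(=O)N(C=O)Cc1ccccc1` differs from compound 2 by formyl in place of hydrogen on an amide-type nitrogen. Going by the values given here, none of the measured steps concerns the amide-type nitrogen; all three alter only the chlorophenyl part, and all three are unreadable. No step beyond the scatter can be predicted in this assay on this basis; the working expectation is that compound 4 also returns a limit.

Compound 4 is expected to give about 200000 nM, in a range from 50000 nM to 1000000 nM. The estimated step that the limit leaves unreadable from compound 2 to compound 4 is thus no change beyond the scatter.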

Compound 4, half-maximal inhibitory concentration: > 100000 nM
Compound 4: a limit, no number; the forecaster's own chance of this, stated with the estimate: 85%; the middle value lies beyond the limit too.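

The step from compound 2 to compound 4 cannot be read, as both compounds return a limit of the assay rather than a number: the limit of > 100000 nM in this assay, at which 4 of the 4 values shown sit.

The compounds shown leave open whether formyl in place of hydrogen on the amide-type nitrogen, or any chloro change, alters inhibition at all, as none has a number of its own.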